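Methoxy in Place of Methyl: What to Expect for Compound 3

The compounds below may be only part of what the source reports. "The series", "measured", "known", "first", "only" and "open" are said of these compounds alone.

Compound 2 `Cc1ccc(-c2cc(NO)c(C(=O)NCCO)c(=O)o2)cc1` was tested in an ADME assay on Huh-7 cells (Homo sapiens) for cytotoxicity, read by a luciferase reporter and WST assay, with a stated time of 3 days; on this read-out lower numbers stand for higher toxicity in this test and higher numbers for lower toxicity in this test. In this assay compound 2 gives > 20000 nM, which is a limit of the assay rather than a number. Compound 1 `CNC(=O)c1c(NO)cc(-c2ccc(OC)cc2)oc1=O`, which already carries a methoxy group on its aryl ring, gives in this assay > 20000 nM, likewise a limit and not a number. Among the compounds with values here, no step between two measured compounds that differ in a single place exists; the only evidence is the limit of > 20000 nM in this assay, at which 2 of the 2 values shown sit. Compound 2 therefore stands at the limit, and on the numbers shown nothing separates it from compound 1.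

Compound 3 `COc1ccc(-c2cc(NO)c(C(=O)NCCO)c(=O)o2)cc1` differs from compound 2 by methoxy in place of methyl on an aromatic carbon, para to a large group. Because the limit of > 20000 nM in this assay, at which 2 of the 2 values shown sit, holds compound 1 with that same methoxy group, the change is not expected to move the read-out. In this assay the step is expected to be a number no higher from compound 2 to compound 3 (the limit leaves the size open), nothing beyond the scatter. Compound 3 is expected to give 20000 nM, within 10000 nM to 40000 nM, and most likely again only a limit.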

Compound 3, half-maximal cytotoxic concentration: > 20000 nM
Compound 3 ended at the assay's limit; the forecaster's own chance of this, stated with the estimate: 85%; the middle value lies on the limit itself.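

In this assay compound 3 gives > 20000 nM, a limit of the assay and not a number. Within the data shown here, no step from compound 2 or compound 1 to compound 3 can be read, because the values stop at the same point: the limit of > 20000 nM in this assay, at which 3 of the 3 values shown sit. The compounds shown leave open at what concentration, if any, each reaches half-maximal cytotoxicity, and so how the three compare.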